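Changing the Acid-Bearing Ring and Its Link

A few compounds are considered here, and "the series" means these few. Any claim that something is new, unique, unknown or untested is made for them only; others in the source may bear on it.

Compound 2 `Cc1c(OCCCCOCOc2ccc(C(=O)O)cc2)ccc(C(=O)CC2CCCC2)c1O` reaches 95.4% in an assay on HEK293 cells for positive allosteric modulation of metabotropic glutamate receptor 2 (Rattus norvegicus), read by thallium flux, with a stated time of 2.5 min (a higher number here means a larger maximal response, a lower number a smaller maximal response), the highest of the three numbers measured. Compound 1 `COc1ccc(C(=O)O)cc1OCCCCOc1ccc(C(=O)CC(C)C)c(O)c1C` gives 89.7%, a value within the usual scatter of that of compound 2, while compound 3 `Cc1c(OCCCCOc2cccc(C(=O)O)c2)ccc(C(=O)CC(C)C)c1O` gives 84.5%, which lies beyond it. Among the compounds with values here, the one measured step that alters a single feature, a number 5.2 percentage points lower from compound 1 to compound 3 (within the scatter), stays within the scatter.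

Compound 4 `Cc1c(OCCCCOc2ccc(C(=O)O)c(Cl)c2)ccc(C(=O)CC2CCCC2)c1O` differs from compound 2 in one place: 4-carboxy-3-chlorophenyl in place of (4-carboxyphenoxy)methyl on an oxygen on a saturated carbon. Within the data shown here, the measured step only concerns a small substituent on the aromatic ring that carries the carboxylic acid, and it stayed within the scatter; no measured step covers a change in the group through which that ring is attached. The values of compound 1 and compound 2 also sit within the scatter of each other. On this basis no step beyond the scatter is expected in this assay.

Compound 4 is therefore estimated at 90%, within a range from 75% to 102%. The expected step of a number 5.4 percentage points lower from compound 2 to compound 4 (within the scatter) is small.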

Compound 4, largest response reached (reported as percent of maximum), in percent of the reference or control that the assay uses: 80.8%
Beside the measured number, compound 4's estimate is 9.2 percentage points above it; the range from low to high includes it.
By their numbers in this assay, from the lowest: compounds 4, 3, 1 and 2 (each within the scatter of the next, the first and the last beyond it).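

In this assay, within the data shown here, this is the first change in a single place to reach beyond the scatter, a number 14.6 percentage points lower from compound 2 to compound 4 (beyond the scatter), whereas the earlier step on the acid-bearing ring stayed within it. The group on this oxygen can therefore shift the maximal response measurably, though this single swap removes the (4-carboxyphenoxy)methyl group and brings in 4-carboxy-3-chlorophenyl, so the link and the chlorine change together. Nothing measured here explains why the response falls.

The compounds shown leave open whether the lower value follows the lost link, the added chlorine or both. A plain 4-carboxyphenyl group on the same oxygen would separate these two changes, and a fluorine in place of the chlorine would test whether the halogen's identity matters.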